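This account rests on a few compounds, and the source may have more. Where it says the series, first, only, none or still open, it means among the compounds named here.

Within the data shown here, compound 3 `O=c1ccc(-c2ccc3cn[nH]c3c2)cn1Cc1ccccc1` is the one compound here with an actual number in an ADME assay on microsomes (Mus musculus) for metabolic stability, read by LC-MS, using NADPH, with a stated time of 1 h, tested at 1 uM (a lower number here means slower removal, a higher number faster removal of the compound), where compound 3 gives 157 mL.min-1.g-1. Compound 1 `Nc1n[nH]c2cc(-c3ccc(=O)n(Cc4ccccc4)c3)ccc12` reaches only a limit of the assay, < 10 mL.min-1.g-1, in this assay. Compound 2 `Nc1n[nH]c2cc(-c3ccc(=O)n(Cc4cccc(Cl)c4)c3)ccc12` likewise sits at a limit, < 10 mL.min-1.g-1, in this assay. Compound 4 `O=c1ccc(-c2ccc3cn[nH]c3c2)cn1Cc1cccc(F)c1` differs from compound 3 by fluoro in place of hydrogen on an aromatic carbon. The closest measured step, a step that the two limits leave unreadable from compound 1 to compound 2, cannot be read because the limit of < 10 mL.min-1.g-1 in this assay, at which 2 of the 3 values shown sit, holds both of its ends. The other measured step, an at least 15-fold higher number from compound 1 to compound 3 (1.19 log units; beyond the scatter), alters a different part of the molecule. Among the measured compounds shown here, no measured step therefore sizes this change, and compound 4 is expected to stay within the scatter of compound 3, an estimated 1.2-fold lower number from compound 3 to compound 4 (0.08 log units; within the scatter). Compound 4 is estimated at 130 mL.min-1.g-1, with a range from 60 mL.min-1.g-1 to 280 mL.min-1.g-1.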

Compound 4, intrinsic clearance in microsomes: 160 mL.min-1.g-1
The estimate for compound 4 lay 1.2-fold (0.09 log units) below the measured number, within the range that was stated.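

Moving from benzyl to 3-fluorobenzyl gives the first readable size for a change on this aromatic ring in this assay: a 1.0-fold higher number from compound 3 to compound 4 (0.01 log units; within the scatter). The earlier chloro step could not give this, since both of its ends are limits: the limit of < 10 mL.min-1.g-1 in this assay, at which 2 of the 4 values shown sit.

Fluoro at this place therefore leaves compound 4 reading alike with compound 3, so this swap does not separate the two. From the compounds shown here alone, what a methoxy group or a carboxylic acid at this place would give stays open. So does how a 3-fluorobenzyl group would read on the amino-bearing core of compound 1.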